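Series notes: aryl exchange on the aromatic nitrogen

The source may report more compounds than this note shows. Statements on the series, on what has been measured and on what is new or still open speak of the compounds shown alone.

Measured compounds:
compound 1 `COc1ccccc1-n1nncc1CN1C(=O)C2(C(C#N)=C(N)Oc3c2c2nc4ccccc4nc2c2ccccc32)c2ccccc21` — in a functional assay on HCT-116 cells (Homo sapiens) for antiproliferative activity, read by MTT assay, with a stated time of 48 h (a lower number here means a stronger inhibitor, a higher number a weaker inhibitor), compound 1 gives > 50000 nM, a limit of the assay.
compound 2 `CCOc1ccccc1-n1nncc1CN1C(=O)C2(C(C#N)=C(N)Oc3c2c2nc4ccccc4nc2c2ccccc32)c2ccccc21` — in this assay compound 2 gives > 50000 nM, also a limit.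
compound 3 `Cc1cc(C)cc(-n2nncc2CN2C(=O)C3(C(C#N)=C(N)Oc4c3c3nc5ccccc5nc3c3ccccc43)c3ccccc32)c1` — in this assay compound 3 gives > 50000 nM, again a limit.

Compound 1 stands only as a limit, as do the other two; all three sit at the limit of > 50000 nM in this assay, at which 3 of the 3 values shown sit. The steps among them are therefore unreadable: a step that the two limits leave unreadable from compound 1 to compound 2, a step that the two limits leave unreadable from compound 1 to compound 3 and a step that the two limits leave unreadable from compound 2 to compound 3. Compound 4 `Cc1ccc(-n2nncc2CN2C(=O)C3(C(C#N)=C(N)Oc4c3c3nc5ccccc5nc3c3ccccc43)c3ccccc32)cc1Cl` is not yet measured. It differs from compound 1 in the group on the aromatic nitrogen: 3-chloro-4-methylphenyl in place of 2-methoxyphenyl on an aromatic nitrogen. The measured steps that bear on it are the two aryl exchanges on that same nitrogen, and neither gave a readable size. Within the data shown here, no measured step shows any aryl on this nitrogen leaving the limit, so no shift beyond the scatter can be expected in this assay in either direction, and the most probable outcome for compound 4 is once more a limit. Compound 4 is therefore estimated at 50000 nM with a range of 25000 nM to 100000 nM. The step this implies, a number no higher from compound 1 to compound 4 (the limit leaves the size open), is an expectation only.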

Compound 4, half-maximal inhibitory concentration: > 50000 nM
Compound 4: only a limit was reported; the forecaster's own chance of this, stated with the estimate: 85%; the middle value sits exactly at the limit.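

The steps to compound 4 from compound 1, compound 2 and compound 3 cannot be read, since all four compounds stand at one limit: the limit of > 50000 nM in this assay, at which 4 of the 4 values shown sit.

The compounds shown leave open whether any aryl group on the aromatic nitrogen brings the shared core to a numerical value in this assay.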